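The compounds below may be only part of what the source reports. "The series", "measured", "known", "first", "only" and "open" are said of these compounds alone.

Compound 2 `O=C1NC(=O)C(Cc2ccc(Oc3ccc(Cl)cc3Cl)cc2C(F)(F)F)S1`: 88 nM
Compound 1 `Cc1ccc(Oc2ccc(CC3SC(=O)NC3=O)cc2)cc1`: 547 nM

In a functional assay for agonist activity at Free fatty acid receptor 1 (Homo sapiens), read by FLIPR, in the presence of a further agent that is not named here (on this read-out lower numbers stand for an effect already at smaller amounts and higher numbers for an effect only at larger amounts of compound), compound 2 gives 88 nM and compound 1 gives 547 nM. Compound 2 thus stands at the lower of the two numbers, and its gap to compound 1 is beyond the usual scatter. Compound 3 `COc1cc(Oc2ccc(Cl)cc2Cl)ccc1CC1SC(=O)NC1=O` has not yet been measured. It differs from compound 2 in a single place: methoxy in place of trifluoromethyl on an aromatic carbon. Going by the values given here, no measured pair shows this particular change, so its effect is unknown. The step is expected to be modest, toward higher numbers, at the edge of the scatter: a 2.3-fold higher number from compound 2 to compound 3 (0.36 log units; beyond the scatter). Compound 3 is therefore estimated at 200 nM in this assay, with a range from 50 nM to 800 nM.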

Compound 3, half-maximal effective concentration: 1410 nM
Compound 3: middle estimate off by 7.1-fold (0.85 log units), on the low side; measured number above the stated range.
By their numbers in this assay, from the lowest: compound 2; then compound 1; then compound 3.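

On this aromatic carbon, ortho to the (2,4-dioxo-1,3-thiazolidin-5-yl)methyl group, the choice of substituent matters: in this assay, methoxy in place of trifluoromethyl gives a 16-fold higher number from compound 2 to compound 3 (1.20 log units; beyond the scatter) and is a large step. Compound 1 and compound 2 differ in more than one place, so they could not isolate this position. Nothing measured here explains the step. Still open, going by these compounds, is whether a chlorine, a nitrile or an amine on this carbon would give a number closer to compound 2 or to compound 3.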